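Fluoro in Place of Methyl: What to Expect for Compound 4

A few compounds are considered here, and "the series" means these few. Any claim that something is new, unique, unknown or untested is made for them only; others in the source may bear on it.

Compound 1 `COc1ccc2cc(C(C)c3nnc4n3N=C(c3ccc(C(F)(F)F)cc3)CS4)ccc2c1`: 6900 nM
Compound 2 `COc1ccc2cc(C(C)c3nnc4n3N=C(c3ccc(C)cc3)CS4)ccc2c1`: 11000 nM
Compound 3 `CC(C)Cc1ccc(C(C)c2nnc3n2N=C(c2ccc(Cl)cc2)CS3)cc1`: 8800 nM

In a functional assay on MCF7 cells (Homo sapiens) for inhibition, read by sulforhodamine B assay, with a stated time of 72 h (on this read-out higher numbers stand for weaker inhibition and lower numbers for stronger inhibition), compound 2 gives 11000 nM, the largest of the three numbers, yet its gaps to compound 3 and to compound 1 both lie within the scatter. Compound 4 `COc1ccc2cc(C(C)c3nnc4n3N=C(c3ccc(F)cc3)CS4)ccc2c1` differs from compound 2 in one place: fluoro in place of methyl on an aromatic carbon. Within the data shown here, the only measured step at this aromatic carbon is a 1.6-fold higher number from compound 1 to compound 2 (0.20 log units; within the scatter), which stayed within the scatter; compound 3 carries chloro at the same place on a different core and gives 8800 nM, again close to the others. Nothing here points to a step beyond the scatter, so for compound 4 the expected step is a 1.2-fold lower number from compound 2 to compound 4 (0.09 log units; within the scatter). Compound 4 is therefore estimated at 9000 nM, within 4000 nM to 20000 nM.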

Compound 4, half-maximal inhibitory concentration: 15800 nM
The estimate for compound 4 lay 1.8-fold (0.24 log units) below the measured number, within the range that was stated.
By their numbers in this assay, from the lowest: compounds 1, 3, 2 and 4 (each within the scatter of the next, the first and the last beyond it).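

In this assay, replacing the methyl with fluoro gives a 1.4-fold higher number from compound 2 to compound 4 (0.16 log units; within the scatter) and so does not separate the two compounds. The same position does yield its first step beyond the scatter, though only a modest one, when fluoro replaces trifluoromethyl: a 2.3-fold higher number from compound 1 to compound 4 (0.36 log units; beyond the scatter) on the shared core. No measurement is available here to account for that step.

The compounds shown leave open how an amine or a carboxylic acid at this place would read, and whether fluoro would give a similar number on the core of compound 3.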